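Removing a Ring Fluorine: Expected Effect on Cell Growth Inhibition

This account rests on a few compounds, and the source may have more. Where it says the series, first, only, none or still open, it means among the compounds named here.

Compound 1, `O=c1c(C2N=C(c3ccccc3)SS2)coc2cc(Cl)c(Cl)cc12`: 58000 nM
Compound 2, `O=c1c(C2N=C(c3ccccc3)SS2)coc2ccc(F)cc12`: 14600 nM

In a functional assay on IMR-32 cells (Homo sapiens) for inhibition, read by sulforhodamine B assay, with a stated time of 48 h (a lower number here means a stronger inhibitor, a higher number a weaker inhibitor), compound 1 gives 58000 nM, while compound 2 gives 14600 nM. Compound 2 thus stands as the lower of the two numbers, and the gap to compound 1 lies beyond the usual scatter of this assay.

Compound 3, `O=c1c(C2N=C(c3ccccc3)SS2)coc2ccccc12`, has not yet been measured in this assay. It differs from compound 2 by hydrogen in place of fluoro on an aromatic carbon, in words: hydrogen in place of fluoro on an aromatic carbon. Among the compounds with values here, no pair of measured compounds isolates this change, so no measured step can be borrowed. Compound 1 carries two chloro groups and gives a higher number, but the shown numbers do not separate the contribution of a single halogen. I expect the step of a 1.5-fold higher number from compound 2 to compound 3 (0.18 log units; within the scatter) to be small, toward a somewhat higher number, or none beyond the scatter. Compound 3 is therefore estimated at 22000 nM, with a range from 8000 nM to 60000 nM.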

Compound 3, half-maximal inhibitory concentration: 16500 nM
The estimate for compound 3 lay 1.3-fold (0.12 log units) above the measured number; the range from low to high includes it.
By their numbers in this assay, from the lowest: compounds 2 and 3 (each within the scatter of the next); then compound 1.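

In this assay, putting hydrogen in place of fluoro on this aromatic carbon, meta to a fused ring and para to a fused ring, gives a 1.1-fold higher number from compound 2 to compound 3 (0.05 log units; within the scatter) and leaves compound 2 and compound 3 indistinguishable. This is the first pair shown that differs in one place only, and it shows that the fluoro group at this carbon is not needed to keep this level of growth inhibition. Nothing measured here explains why the swap leaves the number within the scatter.

On these data alone, whether an amine, a carboxylic acid or a longer chain on this same carbon would move the number stays open. As far as these compounds go, it also remains unknown whether a single change elsewhere on the shared core would give a step beyond the scatter.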